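A chloro substituent on the phenyl ring of compound 3

The source may report more compounds than this note shows. Statements on the series, on what has been measured and on what is new or still open speak of the compounds shown alone.

Compound 1, `O=C(O)C[C@H](O)C[C@H](O)CCn1c(C(F)(F)F)nc(-c2ccc(F)cc2)c1-c1ccc(F)cc1`, in an assay on microsomes from liver for inhibition of 3-hydroxy-3-methylglutaryl-coenzyme A reductase (Rattus norvegicus); a higher number here means a weaker inhibitor, a lower number a stronger inhibitor: 38 nM
Compound 2, `Cc1cc(-c2nc(C(F)(F)F)n(CC[C@@H](O)C[C@@H](O)CC(=O)O)c2-c2ccc(F)cc2)cc(C)c1F`, in this assay: 32 nM
Compound 3, `O=C(O)C[C@H](O)C[C@H](O)CCn1c(C(F)(F)F)nc(-c2ccc(F)cc2)c1-c1ccccc1`, in this assay: 201 nM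

Compound 3 has the highest number of the three in this assay; the step of a 5.3-fold higher number from compound 1 to compound 3 (0.72 log units; beyond the scatter) separates it from compound 1, and compound 2 lies further off still. Compound 4, `O=C(O)C[C@H](O)C[C@H](O)CCn1c(C(F)(F)F)nc(-c2ccc(F)cc2)c1-c1cccc(Cl)c1`, differs from compound 3 by chloro in place of hydrogen on an aromatic carbon. Among the compounds with values here, the only measured step that touches this ring is a 5.3-fold higher number from compound 1 to compound 3 (0.72 log units; beyond the scatter), where a halogen on the ring went with a clearly lower number; the step of a 1.2-fold lower number from compound 1 to compound 2 (0.07 log units; within the scatter) concerns the other phenyl ring and gives no guide. A downward step a 2.2-fold lower number from compound 3 to compound 4 (0.35 log units; beyond the scatter) is therefore expected for compound 4, though with wide uncertainty since both halogen and place differ. Compound 4 is estimated at 90 nM, within 35 nM to 250 nM.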

Compound 4, half-maximal inhibitory concentration: 41 nM
Compound 4: middle estimate off by 2.2-fold (0.34 log units), on the high side, within the range that was stated.
By their numbers in this assay, from the lowest: compounds 2, 1 and 4 (each within the scatter of the next); then compound 3.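

In this assay the step of a 4.9-fold lower number from compound 3 to compound 4 (0.69 log units; beyond the scatter) shows that chloro on an aromatic carbon, meta to a large group, also goes with a clearly lower number, so the halogen gain on this ring is not confined to the fluoro of compound 1. The step of a 1.1-fold higher number from compound 1 to compound 4 (0.03 log units; within the scatter) lies within the scatter, so 3-chlorophenyl and 4-fluorophenyl cannot be told apart here. No evidence is available to explain this result.

Left open is whether methoxy or an amine at this same place would match chloro, and whether 3-fluorophenyl would match 3-chlorophenyl.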